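Swapping bromo for nitro in sulfonamide acidity

A few compounds are considered here, and "the series" means these few. Any claim that something is new, unique, unknown or untested is made for them only; others in the source may bear on it.

Compound 1 `O=S(=O)(Nc1ccccc1)c1cccc(Br)c1` and compound 2 `O=[N+]([O-])c1cccc(S(=O)(=O)Nc2ccccc2)c1` share one core; compound 3 `O=S(=O)(Nc1ccc(Cl)cc1)c1ccc(Br)cc1` and compound 4 `O=[N+]([O-])c1ccc(S(=O)(=O)Nc2ccc(Cl)cc2)cc1` share another, and the difference between the two cores is not broken down here. In a physicochemical assay for acid dissociation, compound 1 gives 8.25 and compound 2 gives 7.5; the change nitro in place of bromo on an aromatic carbon made a step of a number 0.75 log units lower from compound 1 to compound 2 (beyond the scatter). In this assay compound 3 gives 8.24. Compound 4 arises from compound 3 by the same kind of change, (nitro in place of bromo on an aromatic carbon), but here the group sits para to a large group rather than meta to a large group. Because a number 0.75 log units lower from compound 1 to compound 2 (beyond the scatter) was modest, a step of similar or somewhat larger size is expected, a number 0.89 log units lower from compound 3 to compound 4 (beyond the scatter), and compound 4 is therefore estimated at 7.35, expected between 7 and 7.7.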

Compound 4, acid dissociation constant: 6.24
The estimate for compound 4 lay 1.11 log units above the measured number; the whole stated range lies above it.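

In this assay, nitro in place of bromo again lowers the number, but the size differs between the two cores: the new step is a number 2.00 log units lower from compound 3 to compound 4 (beyond the scatter), a large one, against the modest a number 0.75 log units lower from compound 1 to compound 2 (beyond the scatter). The direction of the change carried from one core to the other, but its size did not, and two pairs cannot establish a rule. The pairs differ in their core, and the nitro in compound 4 sits para to a large group, so they cannot show which of these sets the size, and nothing available here explains the difference.

The compounds shown leave open how a nitrile or a trifluoromethyl in place of bromo would behave on these cores. They also leave open whether nitro para to a large group gives a similar step on the core of compound 1.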